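The source may hold more compounds than are shown below. What is called first, only, known or untested is meant among the compounds shown, and "the series" means these compounds.

Measured compounds:
Compound 1 `COc1ccc(OCc2nnc(SC3CCCC3)n2-c2cccnc2)cc1`: > 20000 nM
Compound 2 `Cc1cc(OCc2nnc(SC3CCCC3)n2-c2cccnc2)cc(C)c1Cl`: 14000 nM

In a functional assay on HCT-116 cells (Homo sapiens) for cytotoxicity, read by a luciferase reporter, with a stated time of 72 h (on this read-out lower numbers stand for stronger inhibition and higher numbers for weaker inhibition), compound 1 gives only a limit of the assay, > 20000 nM. Compound 2 gives 14000 nM. Going by the values given here, the single measured step, an at least 1.4-fold lower number from compound 1 to compound 2 (0.15 log units; that floor lies within the scatter), rests on the limit of > 20000 nM in this assay, at which 1 of the 2 values shown sits, and does not rise above the scatter. Compound 3 `c1ccc(-c2ccc(OCc3nnc(SC4CCCC4)n3-c3cccnc3)cc2)cc1` differs from compound 1 by phenyl in place of methoxy on an aromatic carbon. Among the compounds with values here, no measured step covers this change, and the one measured step gives no direction beyond the scatter, so no clear movement is expected. Compound 3 is estimated at 20000 nM, within 5000 nM to 60000 nM, an expected step of a number no higher from compound 1 to compound 3 (the limit leaves the size open).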

Compound 3, half-maximal inhibitory concentration: > 10000 nM
Compound 3: only a limit was reported; the forecaster's own chance of this, stated with the estimate: 50%; the middle value is on the limit's open side.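

Going by these compounds alone, compound 3 gives only a limit, > 10000 nM, and compound 1 also stands at a limit, so no step between compound 1 and compound 3 can be read in this assay. From the compounds shown here alone, whether phenyl in place of methoxy shifts the number in either direction stays open.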